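Pyridyl for fluorophenyl swap in a chalcone series

This account rests on a few compounds, and the source may have more. Where it says the series, first, only, none or still open, it means among the compounds named here.

Measured compounds:
Compound 1 `COc1ccc(/C=C/C(=O)c2ccccc2-c2ccc(F)cc2)cc1`: in a functional assay on CNE-2 cells (Homo sapiens) for antiproliferative activity, read by sulforhodamine B assay, with a stated time of 48 h (on this read-out higher numbers stand for weaker inhibition and lower numbers for stronger inhibition), compound 1 gives 53 nM.
Compound 2 `COc1ccc(/C=C/C(=O)c2ccccc2-c2ccc(F)nc2)cc1`: in this assay compound 2 gives 160 nM.
Compound 3 `COc1cc(C(=O)/C=C/c2ccccc2-c2ccc(F)cc2)ccc1O`: in this assay compound 3 gives 4800 nM.

Compound 1 and compound 2 differ in one place only: 6-fluoropyridin-3-yl in place of 4-fluorophenyl on an aromatic carbon. That change produced a 3.0-fold higher number from compound 1 to compound 2 (0.48 log units; beyond the scatter), a modest step beyond the usual scatter.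

Compound 3 has the highest number of the three in this assay, standing well above compound 2 and further still above compound 1. The difference between the core of compound 3 and the core of compound 1 is not broken down here.

Compound 4 `COc1cc(C(=O)/C=C/c2ccccc2-c2ccc(F)nc2)ccc1O` is not yet measured. It stands to compound 3 as compound 2 stands to compound 1: 6-fluoropyridin-3-yl in place of 4-fluorophenyl on an aromatic carbon. The place of the change is described in the same words for both pairs, so it is the same change, made on a different core.

Among the compounds with values here, the expectation for compound 4 rests on the single earlier instance of this change, the step from compound 1 to compound 2, a 3.0-fold higher number from compound 1 to compound 2 (0.48 log units; beyond the scatter). Compound 4 is therefore expected to give a higher number than compound 3, with the step estimated at a 2.5-fold higher number from compound 3 to compound 4 (0.40 log units; beyond the scatter). Within the data shown here, only one earlier pair is available, and the cores of compound 3 and compound 1 are not compared in detail. The range around the estimate is kept wide. Compound 4 is estimated at 12000 nM, between 4000 nM and 40000 nM.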

Compound 4, half-maximal inhibitory concentration: 19000 nM
Beside the measured number, compound 4's estimate is 1.6-fold (0.20 log units) below it; the measured number falls inside the stated range.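

Placed in the second core, the change from 4-fluorophenyl to 6-fluoropyridin-3-yl again raised the number in this assay, with a 4.0-fold higher number from compound 3 to compound 4 (0.60 log units; beyond the scatter), a modest step in the same direction as the one seen earlier. The two steps agree in direction, and their sizes cannot be told apart: the same change on two cores in this assay, a 3.0-fold higher number (0.48 log units; beyond the scatter) from compound 1 to compound 2 and a 4.0-fold higher number (0.60 log units; beyond the scatter) from compound 3 to compound 4, 1.3-fold (0.12 log units) apart, within the scatter of two such steps. In this series, then, the change carried over between the two cores with its direction and approximate size intact, but two pairs show only that agreement, and they neither establish a rule for any further core nor explain why the number rises in either pair.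

The compounds shown leave open how the number would respond if the fluorine on the 6-fluoropyridin-3-yl group gave way to another substituent, such as an amine or a carboxylic acid, and whether those groups would act alike on both cores. They also leave open whether the agreement between the two steps would hold on a third core, or in antiproliferative testing on cell lines other than the one used here.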